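Fluoro in Place of Allyloxy: Expected Cytotoxicity Outcome

A few compounds are considered here, and "the series" means these few. Any claim that something is new, unique, unknown or untested is made for them only; others in the source may bear on it.

Compound 1 `C=CCOc1cc(C2=C(c3cc(OC)c(OC)c(OC)c3)C(=O)C(O)C2)ccc1OC`: > 100 ug/mL
Compound 2 `COc1ccc(OC)c(C2=C(c3cc(OC)c(OC)c(OC)c3)C(=O)CC2O)c1`: > 100 ug/mL

Both compounds were tested in an ADME assay on PA-1 cells (Homo sapiens) for cytotoxicity, read by MTT assay, with a stated time of 72 h; a higher number here means a weaker inhibitor, a lower number a stronger inhibitor. For compound 1 the reading of > 100 ug/mL is a limit of the assay, not a measured number. For compound 2 the reading of > 100 ug/mL is likewise a limit. The two readings therefore sit together at the limit of > 100 ug/mL in this assay, at which 2 of the 2 values shown sit, so compound 1 stands at the limit with nothing to rank it against.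

Compound 3 `COc1ccc(C2=C(c3cc(OC)c(OC)c(OC)c3)C(=O)C(O)C2)cc1F` has not yet been measured. It differs from compound 1 by fluoro in place of allyloxy on an aromatic carbon. Among the measured compounds shown here, no step between measured compounds is available to calibrate this change, so the expectation is no step beyond the usual scatter in this assay . Compound 3 is expected to give about 100 ug/mL, within a range from 30 ug/mL to 300 ug/mL. The expected step is a number no higher from compound 1 to compound 3 (the limit leaves the size open), because compound 1 already sits at the limit of > 100 ug/mL in this assay, at which 2 of the 2 values shown sit.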

Compound 3, half-maximal inhibitory concentration: > 100 ug/mL
Compound 3: no number, only a limit (the forecaster's own chance of this, stated with the estimate: 70%); the middle value sits exactly at the limit.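

No step can be read between compound 1 and compound 3, since both readings are limits and not numbers: the limit of > 100 ug/mL in this assay, at which 3 of the 3 values shown sit.

The compounds shown leave open how fluoro and allyloxy compare in this assay, and what number any of these compounds would give there.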